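A few compounds are considered here, and "the series" means these few. Any claim that something is new, unique, unknown or untested is made for them only; others in the source may bear on it.

Series notes, cytotoxicity readings. Compound 1 `Cc1ccc(-c2nc3ccccc3s2)cc1NC(=O)c1cc([N+](=O)[O-])c(N2CCCCC2)cc1Cl` carries a piperidin-1-yl group on the shared core. In an ADME assay on BJ cells (Homo sapiens) for cytotoxicity, with a stated time of 72 h (a lower number here means that less compound is needed, a higher number that more compound is needed for the effect), compound 1 gives > 25000 nM, which is a limit of the assay and not a number. Compound 2 `O=C(Nc1cc(-c2nc3ccccc3o2)ccc1F)c1cc([N+](=O)[O-])ccc1Cl` is the other measured member. In this assay compound 2 gives > 25000 nM, again a limit rather than a number. Within the data shown here, compound 1 thus stands at the limit of > 25000 nM in this assay, at which 2 of the 2 values shown sit; no member of the series has returned a numeric value. Among the measured compounds shown here, no step between two measured compounds is available, so the size of any single change in this assay cannot be read from the data.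

Compound 3 `COC(=O)C1CCN(c2cc(Cl)c(C(=O)Nc3cc(-c4nc5ccccc5s4)ccc3C)cc2[N+](=O)[O-])CC1` is not yet measured. It differs from compound 1 as follows: methoxycarbonyl in place of hydrogen on a saturated ring carbon. The rest of the structure is unchanged. For the measured compounds named here, with both measured values sitting at the limit, the expectation is that compound 3 shows no step in this assay beyond the scatter in either direction. The expected step is a step that the limit leaves unreadable from compound 1 to compound 3. Compound 3 is estimated at 40000 nM, with a range from 15000 nM to 120000 nM, and is most likely to be reported again only as a limit.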

Compound 3, half-maximal effective concentration: > 25000 nM
Compound 3 ended at the assay's limit; the forecaster's own chance of this, stated with the estimate: 85%; the middle value lies beyond the limit too.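

In this assay compound 3 gives > 25000 nM, a limit and not a number, so the difference between compound 1 and compound 3 cannot be read as a step. The compounds shown leave open what numeric value any member of the series would return and how large any single change would be, because all readings share one limit: the limit of > 25000 nM in this assay, at which 3 of the 3 values shown sit.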